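Trifluoromethyl on the aryl piperazine across two cores

A few compounds are considered here, and "the series" means these few. Any claim that something is new, unique, unknown or untested is made for them only; others in the source may bear on it.

Measured compounds:
compound 1, `O=C1C2CCCN2C(=O)N1CCCN1CCN(c2ccccc2)CC1`, 15.4 nM
compound 2, `O=C1C2CCCN2C(=O)N1CCCN1CCN(c2cccc(C(F)(F)F)c2)CC1`, 109 nM
compound 3, `O=C1C2CCCCN2C(=O)N1CCCCN1CCN(c2ccccc2)CC1`, 18.6 nM

In an assay on isolated protein for binding affinity to Adrenergic receptor alpha-1 (Rattus norvegicus), read by radioligand binding (on this read-out lower numbers stand for stronger inhibition and higher numbers for weaker inhibition), compound 1 gives 15.4 nM and compound 3 gives 18.6 nM; these two numbers lie within the usual scatter of each other, so no order between them is claimed. Compound 1 and compound 3 have different cores, and the difference between the two cores is not broken down here.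

Compound 2 carries the change trifluoromethyl in place of hydrogen on an aromatic carbon relative to compound 1. Going by the values given here, the step of a 7.1-fold higher number from compound 1 to compound 2 (0.85 log units; beyond the scatter) is the only measured instance of this change in the set.

Compound 4, `O=C1C2CCCCN2C(=O)N1CCCCN1CCN(c2cccc(C(F)(F)F)c2)CC1`, is not yet measured. It differs from compound 3 by trifluoromethyl in place of hydrogen on an aromatic carbon, which is the same change as that from compound 1 to compound 2, made on the core of compound 3 instead. With one measured instance, the expectation for compound 4 rests on that single step and on compound 3 standing at 18.6 nM. The step from compound 3 to compound 4 is expected to be of the order of a 6.5-fold higher number from compound 3 to compound 4 (0.81 log units; beyond the scatter), close to the step seen for compound 1 to compound 2 because of a 7.1-fold higher number from compound 1 to compound 2 (0.85 log units; beyond the scatter), with the wider range reflecting that a second core may carry the change differently. Compound 4 is accordingly estimated at 120 nM, between 45 nM and 320 nM.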

Compound 4, inhibition constant: 72.4 nM
Compound 4: the middle estimate sits 1.7-fold (0.22 log units) above what was measured; the measured number falls inside the stated range.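

In this assay, trifluoromethyl in place of hydrogen on an aromatic carbon also gives a higher number on the second core, with a 3.9-fold higher number from compound 3 to compound 4 (0.59 log units; beyond the scatter), so the direction of the change carries over from the core of compound 1 to the core of compound 3. Going by these compounds alone, the size of the step also shows no difference that can be told apart between the two cores: the same change on two cores in this assay, a 7.1-fold higher number (0.85 log units; beyond the scatter) from compound 1 to compound 2 and a 3.9-fold higher number (0.59 log units; beyond the scatter) from compound 3 to compound 4, 1.8-fold (0.26 log units) apart, within the scatter of two such steps This rests on only two pairs, so it supports carrying the change between these two cores alone; it does not show that the step would hold on any other core, and it gives no reason for the higher numbers.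

Open, from the compounds shown here alone, is whether another group in the same place on the ring, such as methoxy, a chlorine atom or a nitrile, would give a step of similar direction and size on both cores. Also open, going by these compounds, is whether the step would persist with a longer chain between the core and the ring that carries the trifluoromethyl.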